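Fluoro for Bromo on a Hydroxypiperidine Sulfone: Expected Step

A few compounds are considered here, and "the series" means these few. Any claim that something is new, unique, unknown or untested is made for them only; others in the source may bear on it.

Measured so far:
compound 1, `O=S(=O)(c1ccc(Br)cc1)c1nc2ccccc2nc1N1CCCC1`: > 50000 nM
compound 2, `O=S(=O)(c1ccc(F)cc1)c1nc2ccccc2nc1N1CCCC1`: 12400 nM
compound 3, `O=S(=O)(c1ccc(Br)cc1)c1nc2ccccc2nc1N1CCCC(O)C1`: 3690 nM

Of the compounds shown here, three have been tested in a functional assay on PC-3 cells (Homo sapiens) for cytotoxicity, read by MTT assay, with a stated time of 72 h; on this read-out higher numbers stand for weaker inhibition and lower numbers for stronger inhibition. For compound 1 the result is a limit of the assay rather than a number: compound 1 gives > 50000 nM. In this assay compound 2 gives 12400 nM and compound 3 gives 3690 nM.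

Two single changes from compound 1 are measured. The first, (fluoro in place of bromo on an aromatic carbon), gave an at least 4.0-fold lower number from compound 1 to compound 2 (0.60 log units; beyond the scatter); because compound 1 sits at the limit of > 50000 nM in this assay, at which 1 of the 3 values shown sits, only a lower bound for this step is known. The second, (3-hydroxypiperidin-1-yl in place of pyrrolidin-1-yl on an aromatic carbon), gave an at least 13-fold lower number from compound 1 to compound 3 (1.13 log units; beyond the scatter), and it also tells how the core of compound 3 differs from the core of compound 1.

Compound 4, `O=S(=O)(c1ccc(F)cc1)c1nc2ccccc2nc1N1CCCC(O)C1`, has not been measured. It differs from compound 3 by fluoro in place of bromo on an aromatic carbon. Going by the values given here, the same change, made at the same place, is the one from compound 1 to compound 2, so compound 4 carries both changes at once. From compound 3 to compound 4 a step of about a 2.8-fold lower number from compound 3 to compound 4 (0.45 log units; beyond the scatter) is expected, resting on an at least 4.0-fold lower number from compound 1 to compound 2 (0.60 log units; beyond the scatter), while allowing that this step is only a lower bound because of the limit of > 50000 nM in this assay, at which 1 of the 3 values shown sits. Compound 4 is estimated at 1300 nM, most likely between 350 nM and 5000 nM.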

Compound 4, half-maximal inhibitory concentration: 2130 nM
Compound 4: middle estimate off by 1.6-fold (0.21 log units), on the low side; measured number inside the range.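

Carried over to the core with the 3-hydroxypiperidin-1-yl group, fluoro in place of bromo gives a 1.7-fold lower number from compound 3 to compound 4 (0.24 log units; within the scatter) in this assay, so compound 3 and compound 4 cannot be told apart in this test. This shows only that a step clearly beyond the scatter was not seen on the second core, and it does not show that the change behaves differently on the two cores: the same change on two cores in this assay, an at least 4.0-fold lower number (0.60 log units; beyond the scatter) from compound 1 to compound 2 and a 1.7-fold lower number (0.24 log units; within the scatter) from compound 3 to compound 4; the limit leaves it open whether they differ

The other change, 3-hydroxypiperidin-1-yl in place of pyrrolidin-1-yl, gives a 5.8-fold lower number from compound 2 to compound 4 (0.77 log units; beyond the scatter), so it goes the same way with fluoro as with bromo, though its size on the two cores cannot be compared: the same change on two cores in this assay, an at least 13-fold lower number (1.13 log units; beyond the scatter) from compound 1 to compound 3 and a 5.8-fold lower number (0.77 log units; beyond the scatter) from compound 2 to compound 4; the limit leaves it open whether they differ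

The compounds shown leave open whether the gain comes from the hydroxyl or from the larger ring, and a plain piperidin-1-yl group or a pyrrolidin-1-yl group carrying a hydroxyl would separate the two. They also leave open how the core with the 3-hydroxypiperidin-1-yl group would respond to other groups in place of bromo or fluoro on the phenyl ring, such as chloro, methoxy or a nitrile.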